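This account rests on a few compounds, and the source may have more. Where it says the series, first, only, none or still open, it means among the compounds named here.

Working notes on the series. In an ADME assay on KB cells (Homo sapiens) for cytotoxicity, read by MTT assay, with a stated time of 72 h (on this read-out higher numbers stand for lower toxicity in this test and lower numbers for higher toxicity in this test), compound 1 (`FC(F)(F)c1ccc(-c2csc(Nc3ccc(Cl)cn3)n2)nc1`) gives 35400 nM, while compound 2 (`COc1ccc(-c2nc(Nc3ccc(Cl)cn3)sc2Cl)nc1`) gives 248000 nM. Compound 2 therefore holds the higher of the two numbers, and its gap to compound 1 lies beyond the usual scatter.

The next entry is compound 3 (`FC(F)(F)c1ccc(-c2nc(Nc3ccc(Cl)cn3)sc2Cl)nc1`), which has not yet been measured. It carries trifluoromethyl in place of methoxy on an aromatic carbon of the six-membered aromatic ring with 1 nitrogen, two atoms from the ring nitrogen and para to a large group: trifluoromethyl in place of methoxy on an aromatic carbon. Among the measured compounds shown here, no measured step isolates this change, so the expectation rests on only two values.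

A clear move to a lower number in this assay, beyond the scatter, is expected because compound 1 stands at 35400 nM and also bears trifluoromethyl. The estimated size of this move is a 4.5-fold lower number from compound 2 to compound 3 (0.65 log units; beyond the scatter). For compound 3 the expected value is 55000 nM, with an estimated range of 18000 nM to 170000 nM.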

Compound 3, half-maximal cytotoxic concentration in the KB assay: > 400000 nM
Compound 3: a limit, no number; the forecaster's own chance of this, stated with the estimate: 10%; middle value at least 7.2-fold (0.86 log units) from the limit.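

In the KB assay compound 3 stands at a limit, not a number: the limit of > 400000 nM in the KB assay, at which 1 of the 3 values shown sits. Trifluoromethyl in place of methoxy on an aromatic carbon gives an at least 1.6-fold higher number from compound 2 to compound 3 (0.20 log units; that floor lies within the scatter), so the lower number seen for compound 1, which also bears trifluoromethyl, does not carry over to this exchange once chloro is present on the shared core, although the floor of this step lies within the scatter. Chloro in place of hydrogen on an aromatic carbon, with trifluoromethyl kept in place, gives an at least 11-fold higher number from compound 1 to compound 3 (1.05 log units; beyond the scatter), a large step beyond the scatter and the clearest reading in this small set.

In a physicochemical assay for solubility, in phosphate buffer, with a stated time of 2 h, at pH 7.4 (a lower number here means a less soluble compound, a higher number a more soluble compound), compound 2 gives < 10000 nM, a limit and not a number. In the physicochemical assay compound 3 gives < 10000 nM, also a limit and not a number. In the physicochemical assay compound 2 and compound 3 both sit at a limit, so the step between them cannot be read: the limit of < 10000 nM in the physicochemical assay, at which 2 of the 2 values shown sit. From the compounds shown here alone, still open in the KB assay are the true size of the upward step to compound 3, whether the chloro step holds with methoxy in place of trifluoromethyl, and whether an amine or a carboxylic acid on this aromatic carbon would give a readable number.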